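The source may report more compounds than this note shows. Statements on the series, on what has been measured and on what is new or still open speak of the compounds shown alone.

Measured compounds:
compound 1 `CCc1ccc(C(=O)NNc2c(Br)cccc2Br)cc1`: > 100000 nM
compound 2 `COc1cccc(C(=O)NNc2c(Br)cccc2Br)c1`: > 100000 nM

In a toxicity assay on MDCK cells (Canis lupus familiaris) for cytotoxicity, read by CCK-8 assay, with a stated time of 48 h (a higher number here means that more compound is tolerated, a lower number that less compound is tolerated), compound 1 gives > 100000 nM as a limit of the assay, not a number. Compound 2 gives > 100000 nM as a limit too. Among the measured compounds shown here, the position of compound 1 is therefore known only as a bound, and it shares that bound with the only other measured compound: the limit of > 100000 nM in this assay, at which 2 of the 2 values shown sit.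

Compound 3 `O=C(NNc1c(Br)cccc1Br)c1ccc(Br)cc1` keeps the core of compound 1 and carries bromo in place of ethyl on an aromatic carbon, para to a large group: bromo in place of ethyl on an aromatic carbon.

For the measured compounds named here, no measured pair differs in one place, so no measured step gives a size for this change. No step beyond the usual scatter is expected, in either direction, and a reading at the limit again is the likeliest outcome. That expectation rests on the measured compounds alone: the limit of > 100000 nM in this assay, at which 2 of the 2 values shown sit.

The expected step of a number no higher from compound 1 to compound 3 (the limit leaves the size open) is estimated to stay within the scatter. In this assay compound 3 is expected at 100000 nM, with an estimated range from 50000 nM to 200000 nM.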

Compound 3, half-maximal cytotoxic concentration: > 100000 nM
Compound 3: no number, only a limit (the forecaster's own chance of this, stated with the estimate: 85%); the middle value sits exactly at the limit.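

Compound 1 and compound 3 both read only as limits in this assay, so the step between them, bromo in place of ethyl on an aromatic carbon, cannot be read. The compounds shown leave open where the true tolerated concentrations lie and whether any change in this series would bring a reading inside the limit: the limit of > 100000 nM in this assay, at which 3 of the 3 values shown sit.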